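Ester to acid in a bis-sulfonamide pair

A few compounds are considered here, and "the series" means these few. Any claim that something is new, unique, unknown or untested is made for them only; others in the source may bear on it.

Measured compounds:
compound 1 `O=S(=O)(Nc1ccc(S(=O)(=O)Nc2cccc3ccccc23)cc1)c1ccc(Br)cc1` gives 174000 nM
compound 2 `COC(=O)c1cc(NS(=O)(=O)c2cc(Cl)cc(Cl)c2)ccc1S(=O)(=O)Nc1cc(Br)c(F)cc1C` gives 10300 nM

In an assay on isolated protein for inhibition of NAD-dependent protein deacylase sirtuin-6 (Homo sapiens) (on this read-out lower numbers stand for an effect already at smaller amounts and higher numbers for an effect only at larger amounts of compound), compound 1 gives 174000 nM, while compound 2 gives 10300 nM. Compound 2 therefore stands at the lower of the two numbers, and the gap to compound 1 is beyond the scatter of this assay, so compound 2 is the more potent of the pair.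

Compound 3 `Cc1cc(F)c(Br)cc1NS(=O)(=O)c1ccc(NS(=O)(=O)c2cc(Cl)cc(Cl)c2)cc1C(=O)O` is not yet measured. It differs from compound 2 only in one place: hydrogen in place of methyl on an oxygen next to a carbonyl group, turning a methoxycarbonyl group into a carboxy group. Among the compounds with values here, no measured pair here shows what such a change does in this assay, so the expected step is uncertain and is best set as none beyond the scatter. Compound 3 is thus estimated at 12000 nM, with a likely range from 3000 nM to 50000 nM, which means an expected step of a 1.2-fold higher number from compound 2 to compound 3 (0.07 log units; within the scatter).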

Compound 3, half-maximal effective concentration: 5700 nM
The estimate for compound 3 lay 2.1-fold (0.32 log units) above the measured number; low and high end bracket the measured number.
By their numbers in this assay, from the lowest: compounds 3 and 2 (each within the scatter of the next); then compound 1.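

Within the data shown here, changing the methoxycarbonyl group into a carboxy group gives the only direct reading of this position in this assay, a step of a 1.8-fold lower number from compound 2 to compound 3 (0.26 log units; within the scatter) that lies within the scatter, so the two numbers cannot be told apart. Hydrogen can therefore take the place of methyl on this oxygen without a measurable loss of the effect seen with compound 2, and the methyl is not needed to keep that effect in this test.

Going by these compounds, it stays open whether a different group at this place, such as a primary amide, a hydroxymethyl group or a tetrazole, or a longer ester such as an ethyl ester, would keep the number or shift it beyond the scatter. Nothing measured here gives a reason why the number holds steady across this change.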